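A few compounds are considered here, and "the series" means these few. Any claim that something is new, unique, unknown or untested is made for them only; others in the source may bear on it.

Measured compounds:
- compound 1 `COc1ccc(Cc2cc(-c3ccc(OC)cc3)nn(CC(=O)Nc3ccc(Br)cc3)c2=O)cc1`
- compound 2 `COc1ccc(-c2cc(Cc3cccc(OC)c3)c(=O)n(CC(=O)Nc3ccc(F)cc3)n2)cc1`
- compound 3 `COc1ccc(Cc2cc(-c3ccc(Cl)cc3)nn(CC(=O)Nc3ccc(Br)cc3)c2=O)cc1`

In an assay on HL-60 cells for agonist activity at N-formyl peptide receptor 3 (Homo sapiens), read by calcium flux (on this read-out lower numbers stand for an effect already at smaller amounts and higher numbers for an effect only at larger amounts of compound), compound 1 gives > 50000 nM, which is a limit of the assay and not a number. In this assay compound 2 gives > 50000 nM, likewise only a limit. In this assay compound 3 gives > 50000 nM, again a limit. The three measured values therefore all sit at the limit of > 50000 nM in this assay, at which 3 of the 3 values shown sit, and no ordering among them can be read.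

Compound 3 differs from compound 1 by chloro in place of methoxy on an aromatic carbon, and the step that the two limits leave unreadable from compound 1 to compound 3 cannot be read from the two limits. How the core of compound 2 differs from the core of compound 1 is not broken down here.

Compound 4 `COc1cccc(Cc2cc(-c3ccc(Cl)cc3)nn(CC(=O)Nc3ccc(F)cc3)c2=O)c1` is not yet measured in this assay. It differs from compound 2 by chloro in place of methoxy on an aromatic carbon, the same change as from compound 1 to compound 3, at a place described in the same words. Among the compounds with values here, since compound 2 gives only a limit in this assay, and the one measured instance of this change, a step that the two limits leave unreadable from compound 1 to compound 3, is itself unreadable, the expectation for compound 4 rests only on the observation that every value so far sits at the limit. The step from compound 2 to compound 4 is expected to be a step that the limit leaves unreadable from compound 2 to compound 4, that is, no readable change. Compound 4 is accordingly estimated at 100000 nM, within 30000 nM to 500000 nM, most likely reported again as a limit.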

Compound 4, half-maximal effective concentration: > 50000 nM
Compound 4 gave a limit, no number; the forecaster's own chance of this, stated with the estimate: 85%; the middle value is on the limit's open side.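

In this assay compound 4 gives > 50000 nM as a limit of the assay and not a number. Compound 2 also stands only at a limit, so the change from 4-methoxyphenyl to 4-chlorophenyl between compound 2 and compound 4 yields no readable step. The compounds shown leave open which structural change, if any, would give a measured number, as every value sits at one limit: the limit of > 50000 nM in this assay, at which 4 of the 4 values shown sit.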